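The source may report more compounds than this note shows. Statements on the series, on what has been measured and on what is new or still open speak of the compounds shown alone.

Measured so far:
compound 1 `COc1ccc(Nc2nc(-c3cccc(F)c3)nc3ccc(F)cc23)cc1` — 41100 nM
compound 2 `Fc1cccc(-c2nc(Nc3cccc(Cl)c3)c3cc(F)ccc3n2)c1` — only a limit, > 50000 nM
compound 3 `Oc1ccccc1Nc1nc(-c2cccc(F)c2)nc2ccc(F)cc12` — 46300 nM

In a functional assay on U-937 cells (Homo sapiens) for cytotoxicity, read by MTT assay, with a stated time of 48 h (on this read-out lower numbers stand for stronger inhibition and higher numbers for weaker inhibition), compound 3 gives the highest of the two numbers; its nearest neighbour is compound 1, and a 1.1-fold higher number from compound 1 to compound 3 (0.05 log units; within the scatter) lies within the scatter. Compound 2 reached only a limit in this assay. Compound 4 `Nc1cccc(Nc2nc(-c3cccc(F)c3)nc3ccc(F)cc23)c1` differs from compound 3 by 3-aminophenyl in place of 2-hydroxyphenyl on a nitrogen on an aromatic ring. The two steps that bear on this change are both swaps of the ring on that same nitrogen: a 1.1-fold higher number from compound 1 to compound 3 (0.05 log units; within the scatter) and an at least 1.0-fold lower number from compound 2 to compound 3 (0.03 log units; that floor lies within the scatter), neither of which moved this assay beyond the scatter. The step from compound 3 to compound 4 is therefore expected to stay within the scatter, as a 1.0-fold lower number from compound 3 to compound 4 (0.01 log units; within the scatter). Compound 4 is estimated at 45000 nM, in a range from 20000 nM to 100000 nM.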

Compound 4, half-maximal inhibitory concentration: > 50000 nM
Compound 4 was reported as a limit (the forecaster's own chance of this, stated with the estimate: 40%); middle value at least 1.1-fold (0.04 log units) away from the limit.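

In this assay, compound 4 gives only a limit, not a number. Going by these compounds, with 3-aminophenyl on this nitrogen, the floors of an at least 1.0-fold higher number from compound 3 to compound 4 (0.03 log units; that floor lies within the scatter) and an at least 1.2-fold higher number from compound 1 to compound 4 (0.08 log units; that floor lies within the scatter) show no change beyond the scatter, though the true size of each step remains unknown. The step between compound 2 and compound 4 cannot be read.

How far the compounds at the limit differ stays hidden: the limit of > 50000 nM in this assay, at which 2 of the 4 values shown sit. On these data alone, whether a carboxylic acid or a longer chain ending in an amine on this ring would give a clearly lower number remains open.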